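A Trifluoromethyl Swap Assessed for Dog Clearance

The source may report more compounds than this note shows. Statements on the series, on what has been measured and on what is new or still open speak of the compounds shown alone.

Compound 1 `O=C(O)CCNC(=O)c1ccc(CN(c2ccc(Cl)cc2)c2nc(-c3ccc(OC(F)(F)F)cc3)cs2)cc1` was tested in an in vivo ADME assay on the whole organism (strain beagle) for pharmacokinetics, with Canis familiaris (Canis lupus familiaris) as the target (a lower number here means slower removal, a higher number faster removal of the compound), where compound 1 gives 4.64 mL/min/kg. Among the measured compounds shown here, that is the higher of the two numbers recorded in this assay; the only other compound, compound 2 `O=C(O)CCNC(=O)c1ccc(CN(c2ccc3c(c2)CCCC3)c2nc(-c3ccc(Cl)c(Cl)c3)cs2)cc1`, gives 1.44 mL/min/kg in this assay, and since the two differ in more than one place their values show only that compound 2 is cleared more slowly. Compound 3 `O=C(O)CCNC(=O)c1ccc(CN(c2ccc(Cl)cc2)c2nc(-c3ccc(C(F)(F)F)cc3)cs2)cc1` has not yet been measured. It differs from compound 1 in one place: trifluoromethyl in place of trifluoromethoxy on an aromatic carbon. For the measured compounds named here, no measured pair in this set shares that single change, so nothing can be compared with it directly. The change is expected to move the number little, and the step is estimated at a 1.1-fold lower number from compound 1 to compound 3 (0.04 log units; within the scatter), a step that would stay within the usual scatter. Compound 3 is therefore expected to give about 4.2 mL/min/kg in this assay, most likely between 1.9 mL/min/kg and 9 mL/min/kg.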

Compound 3, clearance: 4.66 mL/min/kg
The estimate for compound 3 lay 1.1-fold (0.05 log units) below the measured number; low and high end bracket the measured number.
By their numbers in this assay, from the lowest: compound 2; then compounds 1 and 3 (each within the scatter of the next).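

In this assay, among the compounds shown here, the step is a 1.0-fold higher number from compound 1 to compound 3 (0.00 log units; within the scatter) and lies within the scatter, the first single-place comparison in this set. At this position, on an aromatic carbon para to a large group, trifluoromethoxy and trifluoromethyl therefore cannot be told apart by clearance in this one pair, and the oxygen that leaves with trifluoromethoxy makes no visible difference here. No measurement available here accounts for this match.

As far as these compounds go, what a nitrile or an amine at this position would give remains open, as does whether the same swap would read alike on a core other than that of compound 1. The lower number of compound 2 also remains unassigned, since it differs from compound 1 and compound 3 in more than one place.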